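The source may report more compounds than this note shows. Statements on the series, on what has been measured and on what is new or still open speak of the compounds shown alone.

Measured compounds in a functional assay on HCT-15 cells (Homo sapiens) for cytotoxicity, read by CCK-8 assay; a higher number here means a weaker inhibitor, a lower number a stronger inhibitor:

Compound 1 `Oc1cccc(-c2cc(-c3ccsc3)cc(-c3ccccc3O)n2)c1` gives > 50000 nM, which is a limit of the assay rather than a number.
Compound 2 `Oc1ccc(-c2cc(-c3ccsc3)cc(-c3ccccc3O)n2)cc1` gives > 50000 nM, again a limit of the assay.
Compound 3 `Oc1cccc(-c2cc(-c3ccco3)cc(-c3ccccc3O)n2)c1` gives > 50000 nM, also a limit of the assay.

Compound 1 and compound 2 share a core and differ in one group: 4-hydroxyphenyl in place of 3-hydroxyphenyl on an aromatic carbon. In this assay the step is a step that the two limits leave unreadable from compound 1 to compound 2, since the values of both compounds sit at the limit of > 50000 nM in this assay, at which 3 of the 3 values shown sit. Compound 1 and compound 3 differ in the five-membered ring: furan-2-yl in place of thiophen-3-yl on an aromatic carbon. That step is a step that the two limits leave unreadable from compound 1 to compound 3, and again both values sit at the limit of > 50000 nM in this assay, at which 3 of the 3 values shown sit.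

Compound 4 `Oc1ccc(-c2cc(-c3ccco3)cc(-c3ccccc3O)n2)cc1` has not yet been measured in this assay. It differs from compound 3 as follows: 4-hydroxyphenyl in place of 3-hydroxyphenyl on an aromatic carbon. This is the same kind of change as that from compound 1 to compound 2, though not the same, for in compound 1 the place is meta to a thiophen-3-yl group while in compound 3 it is meta to a furan-2-yl group. How the two cores differ is given by furan-2-yl in place of thiophen-3-yl on an aromatic carbon.

Because all three measured values sit at the limit of > 50000 nM in this assay, at which 3 of the 3 values shown sit, the earlier step of this kind could not be read, and no other step among these compounds gives a size to carry over. Compound 4 is therefore expected to give 50000 nM, a step of a number no higher from compound 3 to compound 4 (the limit leaves the size open) from compound 3, with a range of 20000 nM to 100000 nM and a high chance that only a limit is reported.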

Compound 4, half-maximal inhibitory concentration: > 50000 nM
Compound 4 was reported as a limit; the forecaster's own chance of this, stated with the estimate: 80%; the middle value sits exactly at the limit.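

In this assay compound 4 gives > 50000 nM, which is a limit of the assay. No new step can be read, neither into compound 4 from compound 3 nor into compound 4 from compound 2, as the values all stand at one limit: the limit of > 50000 nM in this assay, at which 4 of the 4 values shown sit. The compounds shown leave open whether 4-hydroxyphenyl in place of 3-hydroxyphenyl, or furan-2-yl in place of thiophen-3-yl, changes the read-out at all.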